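Moving one nitrile: what compound 4 may show

The source may report more compounds than this note shows. Statements on the series, on what has been measured and on what is new or still open speak of the compounds shown alone.

Measured in a toxicity assay on MT4 cells (Homo sapiens) for cytotoxicity, read by MTT assay; a higher number here means that more compound is tolerated, a lower number that less compound is tolerated
compound 1 `Cc1cc(-c2ccc(C#N)c(C#N)c2)ccc1Oc1cc(N)nc(Nc2ccc(C#N)cc2)n1` gives 76700 nM
compound 2 `Cc1cc(-c2cccc(F)c2)ccc1Oc1cc(N)nc(Nc2ccc(C#N)cc2)n1` gives 11300 nM
compound 3 `Cc1cc(-c2cccc(C#N)c2)ccc1Oc1cc(N)nc(Nc2ccc(C#N)cc2)n1` gives 27400 nM

Compound 3 holds the second highest of these three numbers. Compound 4 `Cc1cc(-c2ccc(C#N)cc2)ccc1Oc1cc(N)nc(Nc2ccc(C#N)cc2)n1` has the same atoms joined differently, with 4-cyanophenyl in place of 3-cyanophenyl on an aromatic carbon. Among the measured compounds shown here, no measured step moves a nitrile, so the evidence is indirect. Two modest steps bear on it. Cyano in place of fluoro gave a 2.4-fold higher number from compound 2 to compound 3 (0.38 log units; beyond the scatter) and hydrogen in place of cyano gave a 2.8-fold lower number from compound 1 to compound 3 (0.45 log units; beyond the scatter) and compound 4 also lacks one nitrile of compound 1. A shift beyond the scatter in this assay is therefore not expected. The estimated step is small, a 1.1-fold higher number from compound 3 to compound 4 (0.04 log units; within the scatter) with no clear direction. Compound 4 is expected near 30000 nM within 12000 nM to 75000 nM as its estimated range.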

Compound 4, half-maximal cytotoxic concentration: 10400 nM
Estimate against measurement, compound 4: 2.9-fold (0.46 log units) above; the whole stated range lies above it.
By their numbers in this assay, from the lowest: compounds 4 and 2 (each within the scatter of the next); then compound 3; then compound 1.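

In this assay, moving the nitrile alone changes the result: 4-cyanophenyl in place of 3-cyanophenyl gives a 2.6-fold lower number from compound 3 to compound 4 (0.42 log units; beyond the scatter) even though the atoms stay the same. Keeping only this nitrile of the 3,4-dicyanophenyl group gives a 7.4-fold lower number from compound 1 to compound 4 (0.87 log units; beyond the scatter) on the same position, while exchanging 3-fluorophenyl for 4-cyanophenyl gives a 1.1-fold lower number from compound 2 to compound 4 (0.04 log units; within the scatter) and so cannot be told apart from no change. Nothing here explains why the nitrile's position matters. Going by these compounds, whether an amine or a carboxylic acid in the place of this nitrile would follow the same trend remains open.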